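The source may hold more compounds than are shown below. What is called first, only, known or untested is meant among the compounds shown, and "the series" means these compounds.

Measured so far in an ADME assay on microsomes from liver (Homo sapiens) for metabolic stability, with a stated time of 10 min; a higher number here means that more of the compound is left, a lower number that less of the compound is left:

compound 1, `CC(C)OC(=O)NCCS(=O)(=O)NC(=O)c1ccc(Nc2nc(NC3(c4ccc(Cl)cc4)CC3)nc(OCC(F)(F)F)n2)cc1`: 100%
compound 2, `CCS(=O)(=O)NC(=O)c1ccc(Nc2nc(NC3(c4ccc(Cl)cc4)CC3)nc(OCC(F)(F)F)n2)cc1`: 100%
compound 3, `O=C(NS(=O)(=O)CCNC(=O)C1CC1)c1ccc(Nc2nc(NC3(c4ccc(Cl)cc4)CC3)nc(OCC(F)(F)F)n2)cc1`: 90%

Compound 3 holds the smallest of the three numbers, yet both neighbouring steps, a number 10 percentage points lower from compound 1 to compound 3 (within the scatter) and a number 10 percentage points lower from compound 2 to compound 3 (within the scatter), lie within the scatter, so nothing here separates it from compound 1 or compound 2. Compound 4, `CN(C)S(=O)(=O)NC(=O)c1ccc(Nc2nc(NC3(c4ccc(Cl)cc4)CC3)nc(OCC(F)(F)F)n2)cc1`, is not yet measured. Its difference from compound 3 is dimethylamino in place of 2-((cyclopropylcarbonyl)amino)ethyl on a sulfonyl sulfur. The earlier changes at the same sulfonyl sulfur, no change at the digits printed from compound 1 to compound 2 (within the scatter) and a number 10 percentage points lower from compound 2 to compound 3 (within the scatter), moved nothing beyond the scatter, so no step beyond the scatter is expected for a number 5 percentage points higher from compound 3 to compound 4 (within the scatter) in this assay. Compound 4 is therefore estimated at 95%, with a range from 80% to 100%.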

Compound 4, percent of the compound remaining: 86%
Estimate against measurement, compound 4: 9 percentage points above; low and high end bracket the measured number.
By their numbers in this assay, from the lowest: compounds 4, 3, 1 and 2 (each within the scatter of the next, the first and the last beyond it).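

In this assay, within the data shown here, dimethylamino on the sulfonyl sulfur gives the first steps at this position that pass the scatter: a number 14 percentage points lower from compound 2 to compound 4 (beyond the scatter) and a number 14 percentage points lower from compound 1 to compound 4 (beyond the scatter). The position is therefore not entirely silent, although the steps are modest and compound 4 stays close to compound 3, with a number 4 percentage points lower from compound 3 to compound 4 (within the scatter). Nothing available here speaks to what lies behind these steps. Still open, on these data alone, is whether the attached nitrogen matters, which methylamino or a morpholine ring on the same sulfur could test. A methyl or a longer plain alkyl chain there would show how far the ethyl result of compound 2 extends.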